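Halogen Swap on the Anilino Group of Compound 2

The source may hold more compounds than are shown below. What is called first, only, known or untested is meant among the compounds shown, and "the series" means these compounds.

Compound 2 `CN1CCN(CCCOc2cccc3nc(Nc4ccc(F)c(F)c4)ccc23)CC1` gives 5130 nM in a functional assay on OVCAR-8 cells (Homo sapiens) for inhibition, read by sulforhodamine B assay, with a stated time of 48 h (on this read-out higher numbers stand for weaker inhibition of growth and lower numbers for stronger inhibition of growth), the lower of the two numbers shown, while compound 1 `CC(C)c1ccc(Nc2ccc3c(OCCCN4CCN(C)CC4)cccc3n2)cc1` gives 17800 nM in this assay. Compound 3 `CN1CCN(CCCOc2cccc3nc(Nc4cc(Cl)cc(Cl)c4)ccc23)CC1` differs from compound 2 by 3,5-dichlorophenyl in place of 3,4-difluorophenyl on a nitrogen on an aromatic ring. For the measured compounds named here, the only measured step at that same nitrogen, a 3.5-fold lower number from compound 1 to compound 2 (0.54 log units; beyond the scatter), involves a different pair of groups, so it bears on this change only loosely. Compound 3 is therefore expected to stay close, with a step of a 1.3-fold lower number from compound 2 to compound 3 (0.11 log units; within the scatter) that need not exceed the scatter. The estimated value of compound 3 in this assay is 4000 nM, within a range from 1500 nM to 12000 nM.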

Compound 3, concentration for 50% growth inhibition: 1940 nM
The estimate for compound 3 lay 2.1-fold (0.31 log units) above the measured number; the range from low to high includes it.
By their numbers in this assay, from the lowest: compound 3; then compound 2; then compound 1.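

In this assay, exchanging one dihalogenated phenyl group for another on this nitrogen still moves the number, with a 2.6-fold lower number from compound 2 to compound 3 (0.42 log units; beyond the scatter) as the result of this change. Measured against the 4-isopropylphenyl group, the 3,5-dichlorophenyl group gives a 9.2-fold lower number from compound 1 to compound 3 (0.96 log units; beyond the scatter) and so places compound 3 lowest of the three. No measurement shown here accounts for either step. The change alters both the halogen and the places it occupies on the ring, so the compounds shown leave open which of these matters. A 3,5-difluorophenyl or 3,4-dichlorophenyl group on this nitrogen would separate the two.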